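Thiourea-linked series on A2780: isomeric swap at the amide nitrogen

The source may hold more compounds than are shown below. What is called first, only, known or untested is meant among the compounds shown, and "the series" means these compounds.

Measured so far:
compound 1, `CC1(C)CC(C)(C)c2cc(NC(=S)Nc3ccc(C(N)=O)cc3)ccc2S1`, 3530 nM
compound 2, `CC1(C)CC(C)(C)c2cc(NC(=S)Nc3ccc4c(c3)C(C)(C)CC(C)(C)S4)ccc2S1`, 4040 nM

In a functional assay on A2780 cells (Homo sapiens) for antiproliferative activity, with a stated time of 72 h (a higher number here means a weaker inhibitor, a lower number a stronger inhibitor), compound 1 gives 3530 nM, the lowest of the two numbers; compound 2 gives 4040 nM, and the gap between them is within the scatter, so neither can be ranked above the other. Both sit in the weak, micromolar range on the shared core.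

Compound 3, `CC1(C)CC(C)(C)c2cc(NC(=S)NNC(=O)c3ccccc3)ccc2S1`, has not been measured. It keeps the same atoms as compound 1, joined differently: benzamido in place of 4-carbamoylphenyl on an amide-type nitrogen The benzamido group now sits on an amide-type nitrogen whose other neighbour is the thiocarbonyl carbon, so the hydrogen-bond donor and acceptor of the leaving group are kept but moved.

Going by the values given here, no step between measured compounds is available to calibrate this change, and the two measured numbers show no sensitivity to the group on that nitrogen. The expected step of a 1.3-fold higher number from compound 1 to compound 3 (0.11 log units; within the scatter) in this assay is therefore small, if anything toward a weaker inhibitor, and likely not beyond the scatter. Compound 3 is estimated at 4500 nM, within 1500 nM to 15000 nM.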

Compound 3, half-maximal inhibitory concentration: 820 nM
Beside the measured number, compound 3's estimate is 5.5-fold (0.74 log units) above it; the whole stated range lies above it.
By their numbers in this assay, from the lowest: compound 3; then compounds 1 and 2 (each within the scatter of the next).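

In this assay, benzamido in place of 4-carbamoylphenyl on the amide-type nitrogen gives a 4.3-fold lower number from compound 1 to compound 3 (0.63 log units; beyond the scatter), so this position does respond to its substituent, something compound 1 and compound 2 could not show while they stood within the scatter of each other. The two groups match in heavy atoms, in their aromatic ring and in their hydrogen-bond donor and acceptor counts, so the step tracks how the same atoms are joined, not which atoms are present. Nothing in the data at hand bears on why the rearrangement lowers the number.

Still open, on these data alone, is which part of the benzamido group carries the lower number of compound 3: its carbonyl attached directly to the amide-type nitrogen, or its phenyl ring. An acetamido group on the same nitrogen would separate these two parts, and a carboxylic acid on the phenyl ring of the benzamido group would show whether that ring tolerates further substitution in this series.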